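The source may report more compounds than this note shows. Statements on the series, on what has been measured and on what is new or still open speak of the compounds shown alone.

Measured so far:
Compound 1 `CCOC(=O)Cn1ncc2c(Nc3ccc(NS(=O)(=O)c4ccc([N+](=O)[O-])cc4)cc3)ncnc21`; in a functional assay on cells (Homo sapiens) for inhibition, read by MTT assay, with a stated time of 72 h (on this read-out higher numbers stand for weaker inhibition and lower numbers for stronger inhibition), compound 1 gives > 64 ug/mL, a limit of the assay.
Compound 2 `O=C(O)Cn1ncc2c(Nc3ccc(NS(=O)(=O)c4ccc([N+](=O)[O-])cc4)cc3)ncnc21`; in this assay compound 2 gives > 100 ug/mL, also a limit.
Compound 3 `CC(=O)Nc1ccc(Nc2ncnc3c2cnn3CC(=O)O)cc1`; in this assay compound 3 gives > 64 ug/mL, again a limit.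

Compound 3 stands at the limit of > 64 ug/mL in this assay, at which 2 of the 3 values shown sit. Compound 2 alone stands at the limit of > 100 ug/mL in this assay, at which 1 of the 3 values shown sits. Within the data shown here, the only measured single step, a step that the two limits leave unreadable from compound 1 to compound 2, cannot be sized between the two limits, and it concerns the ester side of the core, not the change now at hand. Compound 4 `O=C(O)Cn1ncc2c(Nc3ccc(NC(=O)c4ccccc4)cc3)ncnc21` differs from compound 3 by phenyl in place of methyl on a carbonyl carbon. Among the measured compounds shown here, no measured step bears on this change, so the expected step that the limit leaves unreadable from compound 3 to compound 4 rests on the limits alone. Compound 4 is therefore estimated at 80 ug/mL, range 25 ug/mL to 200 ug/mL, most likely reported once more as a limit.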

Compound 4, half-maximal inhibitory concentration: > 100 ug/mL
Compound 4: a limit, no number; the forecaster's own chance of this, stated with the estimate: 70%; middle value at least 1.2-fold (0.09 log units) away from the limit.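

Compound 3 and compound 4 both stand as limits of the assay, so no step can be read between them. Whether phenyl in place of methyl on a carbonyl carbon changes inhibition at all stays open, as does the true half-maximal concentration of each compound shown.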